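The source may hold more compounds than are shown below. What is called first, only, known or untested is meant among the compounds shown, and "the series" means these compounds.

Measured compounds in an assay on isolated protein for binding affinity to growth hormone secretagogue receptor type 1 (Homo sapiens); a higher number here means a weaker inhibitor, a lower number a stronger inhibitor:
compound 1 `CCc1cc(N(CC)CC)ccc1NC(=O)c1c(-c2c(Cl)cccc2Cl)noc1C` gives 370 nM.
compound 2 `CCNc1ccc(NC(=O)c2c(-c3c(Cl)cccc3Cl)noc2C)cc1` gives > 10000 nM, which is a limit of this assay and not a number.
compound 3 `CCN(CC)c1ccc(NC(=O)c2c(-c3c(Cl)cccc3Cl)noc2C)c(C(F)(F)F)c1` gives 4100 nM.

Compound 2 thus stands at the weak end of the three, at the limit described in the limit of > 10000 nM in this assay, at which 1 of the 3 values shown sits, while compound 1 and compound 3 return numbers. Among the measured compounds shown here, the one step measured, an 11-fold higher number from compound 1 to compound 3 (1.04 log units; beyond the scatter), concerns a substituent on an aromatic carbon of the shared core and is large; it does not touch the nitrogen on the aromatic ring at which compound 4 `CCN(C(C)=O)c1ccc(NC(=O)c2c(-c3c(Cl)cccc3Cl)noc2C)cc1` differs from compound 2: acetyl in place of hydrogen on a nitrogen on an aromatic ring. For the measured compounds named here, no measured step therefore bears directly on this change, and compound 1, which carries a different substitution on that nitrogen, differs from compound 2 in more than one place, so its value cannot be read as a step. Because compound 2 sits at the limit of this assay, > 10000 nM, any move beyond the scatter can only be seen if compound 4 returns a number. The step from compound 2 to compound 4 in this assay is expected to be a number no higher from compound 2 to compound 4 (the limit leaves the size open), that is, nothing resolvable. Compound 4 is estimated at 10000 nM, within the range 3000 nM to 30000 nM.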

Compound 4, half-maximal inhibitory concentration: > 10000 nM
Compound 4: only a limit was reported (the forecaster's own chance of this, stated with the estimate: 60%); the middle value lies on the limit itself.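

Compound 2 and compound 4 both return only a limit in this assay, not a number, so no step can be read between them: the limit of > 10000 nM in this assay, at which 2 of the 4 values shown sit.

As far as these compounds go, how acetyl in place of hydrogen on a nitrogen on an aromatic ring shifts the read-out, if it does at all, stays open.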